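Demethylation at a Saturated Carbon Oxygen in a Polyether Core

This account rests on a few compounds, and the source may have more. Where it says the series, first, only, none or still open, it means among the compounds named here.

Compound 2 `COC1=C(OC)[C@@]2(OC)c3c(O)c(OC)c4c(c3O[C@@]23O[C@@H](c2ccccc2)CC=C3C1=O)[C@@H](OC)C[C@H](c1ccccc1)O4` gives the lowest of the two numbers measured in a functional assay on U-373MG ATCC cells for cytotoxicity against U373 MG (Homo sapiens) (on this read-out higher numbers stand for an effect only at larger amounts of compound and lower numbers for an effect already at smaller amounts), namely 0.1 ug/mL. Compound 1 `COC1=C(OC)[C@@]2(OC)c3c(OC)c(OC)c4c(c3O[C@@]23O[C@@H](c2ccccc2)CC=C3C1=O)[C@@H](OC)C[C@H](c1ccccc1)O4` carries a methyl on the aromatic oxygen where compound 2 carries hydrogen. In this assay compound 1 gives 0.8 ug/mL. For the measured compounds named here, the single measured step, an 8.0-fold lower number from compound 1 to compound 2 (0.90 log units; beyond the scatter), lies beyond the scatter. Compound 3 `COC1=C(OC)[C@@]2(OC)c3c(O)c(OC)c4c(c3O[C@@]23O[C@@H](c2ccccc2)CC=C3C1=O)[C@@H](O)C[C@H](c1ccccc1)O4` is the next compound: hydrogen in place of methyl on an oxygen on a saturated carbon. This change sits on an oxygen on a saturated carbon whose other neighbour is a saturated ring carbon, not on the aromatic ring, so the measured step concerns another place and bears on it only loosely. With one step of the same general kind, hydrogen in place of methyl on an oxygen, giving a lower number, a small lowering or no change beyond the scatter is expected. The number for compound 3 in this assay is estimated at 0.08 ug/mL, between 0.025 ug/mL and 0.3 ug/mL, an expected step of a 1.3-fold lower number from compound 2 to compound 3 (0.10 log units; within the scatter).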

Compound 3, half-maximal effective concentration: 0.3 ug/mL
Beside the measured number, compound 3's estimate is 3.8-fold (0.57 log units) below it; the range from low to high includes it.
By their numbers in this assay, from the lowest: compound 2; then compound 3; then compound 1.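

Exchanging methoxy for hydroxy on the saturated carbon does not repeat what the same kind of exchange did on the aromatic ring. In this assay the new change gives a 3.0-fold higher number from compound 2 to compound 3 (0.48 log units; beyond the scatter) and reverses the direction of the earlier 8.0-fold lower number from compound 1 to compound 2 (0.90 log units; beyond the scatter) on the aromatic oxygen. On this core, then, the two oxygens do not respond alike to losing a methyl, and of compounds 2 and 3 the one keeping the methoxy on the saturated carbon gives the lower number. Nothing available accounts for this difference between the two oxygens.

The compounds shown leave open how this position would read with an amine or a longer chain such as ethoxy in place of methoxy. They also leave open whether the hydroxy on the saturated carbon would give the same direction of change with methoxy kept on the aromatic ring.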